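Removing a Methyl from Compound 1

A few compounds are considered here, and "the series" means these few. Any claim that something is new, unique, unknown or untested is made for them only; others in the source may bear on it.

Going by the values given here, compound 1 `CO[C@H]1C=C(COC(C)=O)C(=O)[C@@H]2O[C@@](C)(OC)[C@](C)(OC)O[C@@H]12` is the only compound in this group with a number in an assay on isolated protein for inhibition of glutathione S-transferase P (Homo sapiens), read by spectrophotometry, with a stated time of 3 min; on this read-out lower numbers stand for stronger inhibition and higher numbers for weaker inhibition; in this assay compound 1 gives 62700 nM. Compound 2 `CO[C@]1(C)O[C@H]2[C@H](O)C(CO)=CC(=O)[C@@H]2O[C@@]1(C)OC` has no result in this assay, its entry reading "not determined" (no result reported). Compound 3 `CO[C@]1(C)O[C@H]2[C@@H](O)C=C(COC(C)=O)C(=O)[C@@H]2O[C@@]1(C)OC` differs from compound 1 by hydrogen in place of methyl on an oxygen on a saturated carbon. Among the compounds with values here, no comparable step between measured compounds exists here, so the change is expected to stay within the usual scatter, a step of a 1.0-fold lower number from compound 1 to compound 3 (0.02 log units; within the scatter). Compound 3 is therefore estimated at 60000 nM, between 20000 nM and 200000 nM.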

Compound 3, half-maximal inhibitory concentration: 82500 nM
Estimate against measurement, compound 3: 1.4-fold (0.14 log units) below; the measured number falls inside the stated range.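

Going from methoxy to hydroxy on the shared core gives a 1.3-fold higher number from compound 1 to compound 3 (0.12 log units; within the scatter) in this assay. Going by these compounds alone, this is the first step that can be read at this position, and it shows that the methyl on this oxygen can be replaced by hydrogen with no change beyond the usual scatter. Compound 1 and compound 3 therefore read as equals here.

The compounds shown leave open whether a larger group on this oxygen, such as an ethyl or an acetyl, or an amine in place of the oxygen, would shift the number beyond the scatter. Nothing measured here speaks to why the two compounds read alike.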